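One Substituent Changed, One Estimate Offered

The source may report more compounds than this note shows. Statements on the series, on what has been measured and on what is new or still open speak of the compounds shown alone.

Compound 1: `O=C(Nc1ccc(F)cc1)C(Cl)Cl`, "not determined" (no result reported) in a functional assay on Bel-7402 cells (Homo sapiens) for antiproliferative activity, read by MTT assay, with a stated time of 72 h; a higher number here means a weaker inhibitor, a lower number a stronger inhibitor
Compound 2: `O=C(Nc1ccc(I)cc1)C(Cl)Cl`, 11900 nM in this assay

Among the compounds with values here, compound 2 stands alone among the numbers: its value in this assay is the only one reported, since compound 1 was not determined, so no step between measured compounds can be drawn and nothing shows how large a change to the group on the ring might be.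

Compound 3 is `O=C(Nc1ccc(SC(F)(F)F)cc1)C(Cl)Cl`. It differs from compound 2 in one place: (trifluoromethyl)sulfanyl in place of iodo on an aromatic carbon. Within the data shown here, with no measured step to lean on, the account expects only a modest shift in this assay from compound 2 to compound 3, in no firm direction, and most likely not beyond the usual scatter.

Compound 3 is accordingly estimated at 10000 nM, with a range from 3500 nM to 30000 nM, so that the expected step of a 1.2-fold lower number from compound 2 to compound 3 (0.08 log units; within the scatter) is small.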

Compound 3, half-maximal inhibitory concentration: 3610 nM
Beside the measured number, compound 3's estimate is 2.8-fold (0.44 log units) above it, within the range that was stated.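

With one measured step now available, the position is no longer silent: in this assay, (trifluoromethyl)sulfanyl in place of iodo on an aromatic carbon gives a 3.3-fold lower number from compound 2 to compound 3 (0.52 log units; beyond the scatter), a modest change that lies beyond the usual scatter. This shows that the group on this ring position can move the number measurably, which compound 2 alone could not show. No measurement shown here accounts for the step.

Steps to compound 1 cannot be read, so the fluoro compound gives no further comparison at this position. The compounds shown leave open how an amine, a carboxylic acid or a longer alkyl chain at the same place would read, and whether the lower number seen with the (trifluoromethyl)sulfanyl group would carry over to any other compound.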